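A Halogen Swap on a Shared Core

The compounds below may be only part of what the source reports. "The series", "measured", "known", "first", "only" and "open" are said of these compounds alone.

Of the compounds shown here, three have so far been measured in a functional assay on B16-F10 cells (Mus musculus) for inhibition, read by MTT assay, with a stated time of 72 h; a higher number here means a weaker inhibitor of growth, a lower number a stronger inhibitor of growth. Compound 1 `Clc1ccc(Sc2c(-c3ccc(Br)cc3)[nH]c3ccccc23)cc1` gives 35000 nM. Compound 2 `CCOC(=O)C1CCN(C(=S)Sc2c(-c3ccc(Br)cc3)[nH]c3ccc(C)cc23)CC1` gives 37000 nM, and compound 3 `COc1ccc2[nH]c(-c3ccc(Cl)cc3)c(Oc3ccc(Cl)cc3)c2c1` gives 31000 nM. The number for compound 1 lies between those of compound 2 and compound 3, and both of those gaps fall within the usual scatter, so the three cannot be told apart.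

Compound 4 `Clc1ccc(Sc2c(-c3ccc(Cl)cc3)[nH]c3ccccc23)cc1` has not yet been measured. It differs from compound 1 by chloro in place of bromo on an aromatic carbon; cut one bond further out, the same difference reads 4-bromophenyl to 4-chlorophenyl. Going by the values given here, no pair of measured compounds shows this change on its own, so the data give no step for it. Given how alike the three measured numbers are, the step is expected to be small: no change at the digits printed from compound 1 to compound 4 (within the scatter), in no particular direction and not beyond the scatter. Compound 4 is therefore expected to give 35000 nM in this assay, within a range from 15000 nM to 80000 nM.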

Compound 4, concentration for 50% growth inhibition: 28000 nM
The estimate for compound 4 lay 1.3-fold (0.10 log units) above the measured number; low and high end bracket the measured number.
By their numbers in this assay, from the lowest: compounds 4, 3, 1 and 2 (each within the scatter of the next).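

Going by these compounds alone, compound 4 gives the first pair in which a single change can be read on its own. In this assay, chloro in place of bromo on an aromatic carbon, para to a large group, gives a 1.3-fold lower number from compound 1 to compound 4 (0.10 log units; within the scatter), so at this position the two halogens cannot be told apart. Nothing available on these compounds bears on why the exchange reads this way.

As far as these compounds go, whether this position would respond to a group other than a halogen, such as an amine or a carboxylic acid, remains open, since the pair compares only chloro and bromo. Also open, from the compounds shown here alone, is whether the same exchange would read alike on the other halogen-bearing aromatic ring of the shared core.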